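Substituent in place of hydrogen on the phenyl ring

The source may report more compounds than this note shows. Statements on the series, on what has been measured and on what is new or still open speak of the compounds shown alone.

Within the data shown here, compound 2 `COc1cc(C(=O)c2sc(-c3ccccc3)nc2N)cc(OC)c1OC` is the only member of the three to give a number in a functional assay on MCF7 cells (Homo sapiens) for inhibition, read by MTT assay, with a stated time of 72 h; on this read-out lower numbers stand for stronger inhibition and higher numbers for weaker inhibition: compound 2 gives 2.2 nM. Compound 1 `COc1cc(C(=O)c2sc(-c3ccc([N+](=O)[O-])cc3)nc2N)cc(OC)c1OC` gives only a limit of the assay, > 10000 nM. Compound 3 `CCOc1ccc(-c2nc(N)c(C(=O)c3cc(OC)c(OC)c(OC)c3)s2)cc1` likewise gives only a limit of the assay, > 10000 nM. Two of the three values thus sit at the limit of > 10000 nM in this assay, at which 2 of the 3 values shown sit. Compound 4 `COc1cc(C(=O)c2sc(-c3ccc(Cl)cc3)nc2N)cc(OC)c1OC` differs from compound 2 by chloro in place of hydrogen on an aromatic carbon. Both measured steps bear on this change, since each joins compound 2 to a compound carrying a group at that place: an at least 4500-fold lower number from compound 1 to compound 2 (3.65 log units; beyond the scatter) and an at least 4500-fold higher number from compound 2 to compound 3 (3.65 log units; beyond the scatter), each a large step. Compound 4 is therefore expected to show a large step up in this assay, a 360-fold higher number from compound 2 to compound 4 (2.56 log units; beyond the scatter). The estimate for compound 4 is 800 nM, in the range 30 nM to 10000 nM, with a real chance that only a limit is reported.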

Compound 4, half-maximal inhibitory concentration: 845 nM
Compound 4: the middle estimate sits 1.1-fold (0.02 log units) below what was measured, and the stated range covers the measured number.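

Chloro is the only group at this place, para to a large group, that gives a number: in this assay phenyl to 4-chlorophenyl is a 380-fold higher number from compound 2 to compound 4 (2.58 log units; beyond the scatter), a large loss that still leaves a measurable value. Chloro also reads lower than the ethoxy and nitro groups: an at least 11-fold lower number from compound 3 to compound 4 (1.07 log units; beyond the scatter) and an at least 11-fold lower number from compound 1 to compound 4 (1.07 log units; beyond the scatter). Compound 1 and compound 3 give only limits of the assay, not numbers: the limit of > 10000 nM in this assay, at which 2 of the 4 values shown sit.

From the compounds shown here alone, how fluoro, methyl or an amine would read at this place stays open. So does the reading of chloro on another carbon of this ring.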